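A few compounds are considered here, and "the series" means these few. Any claim that something is new, unique, unknown or untested is made for them only; others in the source may bear on it.

Working notes on the shared core. Two compounds have numbers in an assay on isolated protein for inhibition of 2-Hydroxyacid oxidase 2 (Rattus norvegicus); a lower number here means a stronger inhibitor, a higher number a weaker inhibitor. Compound 1, `Cc1n[nH]c(C(=O)O)c1Cc1cccc(C(F)(F)F)c1`, gives 300 nM in this assay. Compound 2, `Cc1n[nH]c(C(=O)O)c1Cc1ccc(Oc2ccccc2)cc1`, gives 500 nM in this assay. Compound 2 holds the higher of the two numbers, its nearest neighbour being compound 1, yet the gap between them lies within the usual scatter, so the two cannot be ordered against each other. Compound 3, `Cc1n[nH]c(C(=O)O)c1Cc1ccc(C(N)=O)cc1`, is not yet measured. It differs from compound 2 in a single place: carbamoyl in place of phenoxy on an aromatic carbon. Among the compounds with values here, no step between measured compounds covers a change of this kind, so nothing measured anchors its size; the carbamoyl group takes the place of the phenoxy group on an aromatic carbon, para to a large group. For compound 3 a step of a 3.0-fold higher number from compound 2 to compound 3 (0.48 log units; beyond the scatter) is expected in this assay, toward a higher number, modest in size and possibly no larger than the scatter. The estimate for compound 3 in this assay is 1500 nM, with a range from 300 nM to 8000 nM, the wide range reflecting how little measured ground supports it.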

Compound 3, half-maximal inhibitory concentration: 1100 nM
Beside the measured number, compound 3's estimate is 1.4-fold (0.13 log units) above it; low and high end bracket the measured number.
By their numbers in this assay, from the lowest: compounds 1 and 2 (each within the scatter of the next); then compound 3.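

In this assay, within the data shown here, carbamoyl in place of phenoxy on an aromatic carbon, para to a large group, gives a 2.2-fold higher number from compound 2 to compound 3 (0.34 log units; beyond the scatter), a modest change and the only step so far. It shows that this position responds to the change, yet inhibition survives the loss of the whole phenoxy group, including its six-membered aromatic ring, and the arrival of a hydrogen-bond donor, with compound 3 still at 1100 nM. No measurement shown here accounts for the size or direction of this step.

The single step swaps the aromatic ring, the heavy-atom count and the hydrogen-bond donor all at once, so the compounds shown cannot assign the rise in the number to any one of these differences. Also open, going by these compounds, is how a nitrile or a methoxy group on this same carbon would read in this assay, since either would stand as a further point of comparison with both carbamoyl and phenoxy.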